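This account rests on a few compounds, and the source may have more. Where it says the series, first, only, none or still open, it means among the compounds named here.

Measured compounds in a functional assay on HeLa cells (Homo sapiens) for cytotoxicity, read by WST assay, with a stated time of 48 h; a lower number here means a stronger inhibitor, a higher number a weaker inhibitor:

Compound 1 `O[C@@H](c1ccccc1)[C@H]1CO[C@H](c2ccccc2)[C@@H](C/C=C/c2ccccc2)C1` gives 6060 nM.
Compound 2 `COc1cccc([C@H](O)[C@H]2CO[C@H](c3ccc(OC)c(OC)c3)[C@@H](C/C=C/c3ccc(OC)c(OC)c3)C2)c1` gives 21200 nM.
Compound 3 `COc1cccc(/C=C/C[C@H]2C[C@@H]([C@@H](O)c3ccccc3)CO[C@@H]2c2ccccc2)c1` gives 10900 nM.

All three share a core built around the same saturated oxygen-containing ring carrying three aromatic arms, and they differ only in the methoxy groups placed on those arms. Compound 3 and compound 1 differ in one place: hydrogen in place of methoxy on an aromatic carbon. The step this makes, a 1.8-fold lower number from compound 3 to compound 1 (0.25 log units; within the scatter), is within the scatter of the measurement, so the two compounds cannot be told apart by it. How compound 2 differs from compound 3 is not broken down here; their values show a gap that is within the scatter, while the gap from compound 2 to compound 1 is beyond it.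

Compound 4 `COc1ccc(/C=C/C[C@H]2C[C@@H]([C@@H](O)c3ccccc3)CO[C@@H]2c2ccc(OC)c(OC)c2)cc1OC` is not yet measured. It differs from compound 2 in one place: hydrogen in place of methoxy on an aromatic carbon. Among the compounds with values here, this is the same change as the one from compound 3 to compound 1, at the same kind of place, though it sits on a different arm of the core: in the first case the group read as 2-(3-methoxyphenyl)ethenyl, here it reads as hydroxy(3-methoxyphenyl)methyl. Because a 1.8-fold lower number from compound 3 to compound 1 (0.25 log units; within the scatter) stayed within the scatter, a step of similar size is expected here, a 1.5-fold lower number from compound 2 to compound 4 (0.18 log units; within the scatter). For compound 4 the estimated value in this assay is 14000 nM, likely between 6000 nM and 30000 nM.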

Compound 4, half-maximal inhibitory concentration: 15500 nM
For compound 4 the middle estimate is 1.1-fold (0.04 log units) below the measured one; the measured number falls inside the stated range.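

In this assay, putting hydrogen in place of methoxy on an aromatic carbon, which turns hydroxy(3-methoxyphenyl)methyl into hydroxy(phenyl)methyl, gives a 1.4-fold lower number from compound 2 to compound 4 (0.14 log units; within the scatter), so this measurement cannot tell the two compounds apart. Set beside the earlier case of the same swap, made on a different arm, the two steps cannot be told apart either, so in these two pairs the change carries over from one core to the other without a readable difference: the same change on two cores in this assay, a 1.8-fold lower number (0.25 log units; within the scatter) from compound 3 to compound 1 and a 1.4-fold lower number (0.14 log units; within the scatter) from compound 2 to compound 4, 1.3-fold (0.12 log units) apart, within the scatter of two such steps. This agreement is only between two steps too small to read, so it shows neither that this methoxy group has a real effect that transfers nor that it is without any effect, and it covers just these two pairs.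

The compounds shown hold only methoxy or hydrogen at this place, so it stays open whether an amine, a carboxylic acid or a longer chain such as butoxy there would give a step beyond the scatter. Also open, going by these compounds, is what happens when the methoxy groups on the other arms of compound 4 are exchanged one at a time, and whether the hydroxy group matters to this result.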